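The compounds below may be only part of what the source reports. "The series", "measured", "known", "first", "only" and "open" are said of these compounds alone.

Measured compounds:

Compound 1, `CN1CCC(n2cc(S(=O)(=O)c3cccc(F)c3)c3cccnc32)C1`, gives 231 nM in a functional assay on HeLa cells for agonist activity at 5-hydroxytryptamine receptor 6 (Homo sapiens), read by cAMP accumulation and immunoassay; a higher number here means that more compound is needed for the effect, a lower number that less compound is needed.
Compound 2, `O=S(=O)(c1ccccc1Cl)c1cn(C2CCCNC2)c2ncccc12`, gives 50 nM in this assay.

Of these two numbers, compound 2 has the lower one, meaning that less of it is needed for the same effect in this assay; compound 1 sits higher, and the gap between the two lies beyond the usual scatter of repeated measurements. The two structures differ in more than one place, so their values show no single change at work.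

Compound 3, `O=S(=O)(c1cc(Cl)cc(Cl)c1)c1cn(C2CCCNC2)c2ncccc12`, has not yet been measured. It differs from compound 2 in one place: 3,5-dichlorophenyl in place of 2-chlorophenyl on a sulfonyl sulfur. For the measured compounds named here, no measured pair shows what this kind of swap does, so there is no direct guide. Going by the values given here, with only two compounds and no comparable step, the expectation is that compound 3 stays close to compound 2, with a step from compound 2 to compound 3 of a 1.6-fold higher number from compound 2 to compound 3 (0.20 log units; within the scatter) expected, possibly not beyond the scatter. Compound 3 is therefore expected to give about 80 nM in this assay, within a range from 25 nM to 300 nM.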

Compound 3, half-maximal effective concentration: 297 nM
For compound 3 the middle estimate is 3.7-fold (0.57 log units) below the measured one; low and high end bracket the measured number.
By their numbers in this assay, from the lowest: compound 2; then compounds 1 and 3 (each within the scatter of the next).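

In this assay, the group on the sulfonyl sulfur clearly matters: with the rest of the molecule unchanged, putting 3,5-dichlorophenyl in place of 2-chlorophenyl gives a 5.9-fold higher number from compound 2 to compound 3 (0.77 log units; beyond the scatter). For the compounds shown here, this is the first pair here that differs in one place, so it gives the first direct reading of this position, and the swap means that more compound is needed for the same effect. Nothing available explains why the number rises.

The swap changes two things at once, since the entering group carries one more chlorine and its chlorines sit at different ring positions, so this single step cannot show which of the two accounts for the rise. A 3-chlorophenyl group would help to separate them, while a phenyl group with no chlorine, or a ring carrying a methoxy group or a nitrile, would show whether chlorine itself matters on this ring or whether other groups are tolerated equally well.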